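A Sulfamoylphenyl Replaces Methoxyphenyl on an Aromatic Nitrogen

The compounds below may be only part of what the source reports. "The series", "measured", "known", "first", "only" and "open" are said of these compounds alone.

Compound 3 `COc1ccccc1-n1nncc1CN1C(=O)C2(C(C#N)=C(N)Oc3c2c2nc4ccccc4nc2c2ccccc32)c2ccccc21` is one of three close relatives tested in a functional assay on HepG2 cells (Homo sapiens) for antiproliferative activity, read by MTT assay, with a stated time of 48 h; on this read-out higher numbers stand for weaker inhibition and lower numbers for stronger inhibition. In this assay compound 3 gives a limit, > 50000 nM, and not a number. Compound 1 `N#CC1=C(N)Oc2c(c3nc4ccccc4nc3c3ccccc23)C12C(=O)N(Cc1cnnn1-c1ccccc1Cl)c1ccccc12` likewise returns a limit, > 50000 nM. Compound 2 `N#CC1=C(N)Oc2c(c3nc4ccccc4nc3c3ccccc23)C12C(=O)N(Cc1cnnn1-c1cccc(Br)c1)c1ccccc12` also stops at a limit, > 50000 nM. The three differ only in the aryl group on the aromatic nitrogen: a 2-chlorophenyl in compound 1, a 3-bromophenyl in compound 2 and a 2-methoxyphenyl in compound 3. Because all three sit at the limit of > 50000 nM in this assay, at which 3 of the 3 values shown sit, the steps between them cannot be read: a step that the two limits leave unreadable from compound 1 to compound 2, a step that the two limits leave unreadable from compound 1 to compound 3 and a step that the two limits leave unreadable from compound 2 to compound 3. Compound 4 `N#CC1=C(N)Oc2c(c3nc4ccccc4nc3c3ccccc23)C12C(=O)N(Cc1cnnn1-c1cccc(S(N)(=O)=O)c1)c1ccccc12` is not yet measured. It differs from compound 3 by 3-sulfamoylphenyl in place of 2-methoxyphenyl on an aromatic nitrogen. Within the data shown here, none of the measured steps shows whether a change of this aryl group moves the read-out at all; every one of them is hidden by the limit. The estimated step that the limit leaves unreadable from compound 3 to compound 4 is therefore expected to be essentially none, with compound 4 most likely staying at the limit as well. Compound 4 is expected to give about 60000 nM in this assay, within a range from 15000 nM to 200000 nM.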

Compound 4, half-maximal inhibitory concentration: 21500 nM
Compound 4: the middle estimate sits 2.8-fold (0.45 log units) above what was measured; low and high end bracket the measured number.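

Among these compounds, compound 4 is the first of these relatives to give a number in this assay, which shows that a change of the aryl group on the aromatic nitrogen can move the read-out. The clearest comparison is with the 3-bromophenyl group, where only the bromo is exchanged for a sulfamoyl and the name keeps the same ring position: this gives an at least 2.3-fold lower number from compound 2 to compound 4 (0.36 log units; beyond the scatter), so the change of group alone is enough, and the other two comparisons give an at least 2.3-fold lower number from compound 3 to compound 4 (0.36 log units; beyond the scatter) and an at least 2.3-fold lower number from compound 1 to compound 4 (0.36 log units; beyond the scatter). These steps state only a minimum size, and the steps among compound 1, compound 2 and compound 3 still cannot be read, because those three compounds stop at a limit: the limit of > 50000 nM in this assay, at which 3 of the 4 values shown sit.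

On these data alone, it remains open whether a 2-sulfamoylphenyl or a 4-sulfamoylphenyl group would give a number like that of compound 4, so the role of the position on the phenyl ring is unsettled. As far as these compounds go, it is equally open whether a carboxylic acid, an amine or a methylsulfonyl group in place of the sulfamoyl would lower the number further, match it or return it to the limit.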